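This account rests on a few compounds, and the source may have more. Where it says the series, first, only, none or still open, it means among the compounds named here.

In a physicochemical assay for lipophilicity, using the shake flask method, measured as octanol-water partition, at pH 7.4 (a higher number here means a more lipophilic compound, a lower number a more polar compound), three compounds sharing one core have been measured: compound 1 (`CC(=O)N[C@@H]1CCC[C@H](C(=O)Nc2cc(-c3cnn4c3CCCC4)c(Cl)cn2)C1`) gives 3.2, compound 2 (`CC(=O)N[C@@H]1CCC[C@H](C(=O)Nc2cc(-c3cnn4c3CCC4)c(Cl)cn2)C1`) gives 2.9 and compound 3 (`CC(=O)N[C@@H]1CCC[C@H](C(=O)Nc2cc(-c3cnc4n3CCC4)c(Cl)cn2)C1`) gives 2.6. Compound 3 therefore stands apart from compound 1 only. That gap is a number 0.60 log units lower from compound 1 to compound 3 (beyond the scatter), whereas a number 0.30 log units lower from compound 2 to compound 3 (within the scatter) and a number 0.30 log units lower from compound 1 to compound 2 (within the scatter) are the two smaller steps. Compound 4 (`CC(=O)N[C@@H]1CCC[C@H](C(=O)Nc2cc(-c3cnn4c3OCCC4)c(Cl)cn2)C1`) carries a group of 9 heavy atoms (6 carbon, 2 nitrogen, 1 oxygen; one five-membered aromatic ring with 2 hetero atoms, one six-membered non-aromatic ring with 2 hetero atoms) in place of a group of 8 heavy atoms (6 carbon, 2 nitrogen; one five-membered non-aromatic ring with 1 hetero atom, one five-membered aromatic ring with 2 hetero atoms), on an aromatic carbon. For the measured compounds named here, the nearest measured comparison is a number 0.60 log units lower from compound 1 to compound 3 (beyond the scatter), since the group left behind there also holds a six-membered non-aromatic ring, but no measured compound has oxygen in this group. In this assay the expected outcome is a number 0.20 log units higher from compound 3 to compound 4 (within the scatter), so no step beyond the scatter is anticipated. Compound 4 is estimated at 2.8, with an expected range from 2.4 to 3.2.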

Compound 4, distribution coefficient: 2.6
Beside the measured number, compound 4's estimate is 0.20 log units above it; the measured number falls inside the stated range.
By their numbers in this assay, from the lowest: compounds 3, 4, 2 and 1 (each within the scatter of the next, the first and the last beyond it).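

For the compounds shown here, compound 4 is the only compound here with oxygen in this group, on the aromatic carbon opposite the ring nitrogen, and in this assay the swap gives no change at the digits printed from compound 3 to compound 4 (within the scatter) and a number 0.30 log units lower from compound 2 to compound 4 (within the scatter). Compared with the other group holding a six-membered non-aromatic ring, it gives a number 0.60 log units lower from compound 1 to compound 4 (beyond the scatter), the same size as a number 0.60 log units lower from compound 1 to compound 3 (beyond the scatter), so a six-membered ring does not by itself keep a compound with compound 1. Nothing available here explains these numbers. The compounds shown leave open where a ring carrying an amine nitrogen in place of this oxygen would fall.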